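Lengthening Ethylamino to Propylamino on a Shared Core

The source may hold more compounds than are shown below. What is called first, only, known or untested is meant among the compounds shown, and "the series" means these compounds.

Compound 1 `CNc1nnc(Cn2c(=O)oc3ccc(C)cc32)s1` gives 21.4%
Compound 2 `CCNc1nnc(Cn2c(=O)oc3ccc(C)cc32)s1` gives 33.8%
Compound 3 `CNC(=S)NNC(=O)Cn1c(=O)oc2ccc(C)cc21` gives 33.8%

All three numbers come from a functional assay on the whole organism for inhibition, with Mus musculus as the target, read by paw edema, with a stated time of 180 min, at a dose of 100 mg/kg by the oral route; on this read-out higher numbers stand for a stronger effect at the one dose given and lower numbers for a weaker effect. Compound 2 stands level with compound 3 at the digits given, and together they hold the highest numbers of the three, while compound 1 sits below them through the step of a number 12.4 percentage points higher from compound 1 to compound 2 (beyond the scatter). Compound 4 `CCCNc1nnc(Cn2c(=O)oc3ccc(C)cc32)s1` differs from compound 2 by methyl in place of hydrogen on a saturated chain carbon, two bonds along the chain from a nitrogen on an aromatic ring; read one bond further out, this is ethyl to propyl, or ethylamino to propylamino. For the measured compounds named here, the only measured step that bears on it is the earlier lengthening, a number 12.4 percentage points higher from compound 1 to compound 2 (beyond the scatter), a modest gain. A second lengthening of the same chain is expected to bring a smaller change, so the step of a number 4.2 percentage points higher from compound 2 to compound 4 (within the scatter) is estimated to be small and upward, probably within the scatter. For compound 4 the estimate is 38%, within 26% to 50%.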

Compound 4, a percentage reported as inhibition, in the whole organism at one dose (the size of the read-out at that dose, not a potency): 31.3%
The estimate for compound 4 lay 6.7 percentage points above the measured number; the range from low to high includes it.
By their numbers in this assay, from the lowest: compounds 1, 4, 2 and 3 (each within the scatter of the next, the first and the last beyond it).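

In this assay, adding one more carbon to the chain gives a number 2.5 percentage points lower from compound 2 to compound 4 (within the scatter), so going from ethylamino to propylamino brings no change that can be told apart from the scatter. Against the shortest chain shown, the longer chain gives a number 9.9 percentage points higher from compound 1 to compound 4 (within the scatter), so the gain beyond the scatter seen with compound 2 is not matched by compound 4. No evidence is available on what lies behind these results.

Going by these compounds, whether a butyl chain or a branched isopropyl group would hold this level remains open. So does the effect of a terminal amine or carboxylic acid on the chain.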